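Iodo for hydrogen, repeated across two drawn isomers

A few compounds are considered here, and "the series" means these few. Any claim that something is new, unique, unknown or untested is made for them only; others in the source may bear on it.

Measured so far in a functional assay on MCF7 cells (Homo sapiens) for cytotoxicity, read by MTT assay, with a stated time of 48 h; on this read-out higher numbers stand for weaker inhibition and lower numbers for stronger inhibition:
compound 1, `C/C(=N/NC(=S)Nc1ccccc1)c1ccccn1`, gives 0.18 nM
compound 2, `C/C(=N/NC(=S)Nc1cccc(I)c1)c1ccccn1`, gives 45 nM
compound 3, `C/C(=N\NC(=S)Nc1ccccc1)c1ccccn1`, gives 0.18 nM

Compound 1 and compound 3 are level in this assay: no change at the digits printed from compound 1 to compound 3 (within the scatter). This rests on (the fact that compounds 1 and 3 differ only in the configuration as drawn), so the drawn configuration by itself does not separate the two in this assay. The one substitution made so far is iodo in place of hydrogen on an aromatic carbon, and it produced a large step: a 250-fold higher number from compound 1 to compound 2 (2.40 log units; beyond the scatter).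

Compound 4, `C/C(=N\NC(=S)Nc1cccc(I)c1)c1ccccn1`, has not yet been measured. It carries the same substitution as compound 2, made on the core of compound 3 instead of the core of compound 1: iodo in place of hydrogen on an aromatic carbon. The two cores differ only in that (the two compounds have the same atoms and bonds and differ only in configuration as drawn: 1 of 1 stereo elements differ; a double bond is drawn Z in compound 1 and E in compound 3). The place of the entering iodo is described in the same words in both cases, so this is the same change, not merely the same kind of change.

Given that compound 3 sits level with compound 1, the next step is expected to be of the same size as the step already seen: a 250-fold higher number from compound 1 to compound 2 (2.40 log units; beyond the scatter). The expected step is estimated as a 250-fold higher number from compound 3 to compound 4 (2.40 log units; beyond the scatter). Compound 4 is therefore expected to give about 45 nM in this assay, most likely between 15 nM and 140 nM.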

Compound 4, half-maximal inhibitory concentration: 45 nM
Compound 4: the middle estimate sits on the measured number at the digits printed; measured number inside the range.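

In this assay, iodo in place of hydrogen on an aromatic carbon gives the step of the first core again on the second, with a 250-fold higher number from compound 3 to compound 4 (2.40 log units; beyond the scatter) as the new reading, and the two steps agree: (the same change on two cores in this assay, a 250-fold higher number (2.40 log units; beyond the scatter) from compound 1 to compound 2 and a 250-fold higher number (2.40 log units; beyond the scatter) from compound 3 to compound 4, 1.0-fold (0.00 log units) apart, within the scatter of two such steps). The iodo pair is also not separated by the configuration as drawn, with no change at the digits printed from compound 2 to compound 4 (within the scatter) as the reading, matching what was seen without iodo: (the fact that compounds 2 and 4 differ only in the configuration as drawn). So this one change carries over at full size between these two cores, but the cores differ only in a drawn double-bond configuration, so the result says nothing about a core with different atoms or bonds, nor does it explain why iodo gives so large a step.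

Still open, on these data alone, is whether a smaller halogen such as fluoro or chloro, or an amine or a carboxylic acid, would give a step of similar size at the same place on the ring, and whether iodo on another carbon of that ring would do the same. Also open, as far as these compounds go, is whether the agreement between the two steps holds for any replacement other than iodo, since a single substitution on two closely related cores is all that can be compared here.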